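This account rests on a few compounds, and the source may have more. Where it says the series, first, only, none or still open, it means among the compounds named here.

Working notes on the pyrazolyl chalcone series in a functional assay on DU-145 cells (Homo sapiens) for cytotoxicity, read by sulforhodamine B assay, with a stated time of 48 h, tested at 0.01 uM; a higher number here means a weaker effect of the compound at the concentration tested, a lower number a stronger effect. Compound 2 (`COc1cc(-c2cc(/C=C/C(=O)c3ccc(N)cc3)[nH]n2)cc(OC)c1OC`) gives 107%, the largest of the three numbers shown, though the gaps to the other two lie within the scatter. Compound 1 (`COc1ccc(-c2cc(/C=C/C(=O)c3ccc(N)cc3)[nH]n2)cc1`) gives 104% and compound 3 (`COc1ccc(C(=O)/C=C/c2cc(-c3cc(OC)c(OC)c(OC)c3)n[nH]2)cc1OC`) gives 104%. Going by the values given here, the one measured step, a number 3 percentage points lower from compound 2 to compound 3 (within the scatter), exchanges the aryl on the carbonyl carbon and leaves the number unchanged beyond the scatter.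

Compound 4 (`COc1ccc(-c2cc(/C=C/C(=O)c3ccc(N)cc3)[nH]n2)cc1OC`) differs from compound 2 as follows: hydrogen in place of methoxy on an aromatic carbon. Among the compounds with values here, no measured step removes a methoxy from this ring, so the change is not directly covered. What the three values do show is that one methoxy in compound 1 and three in compound 2 and compound 3 all sit at essentially no effect at this concentration, so the step of a number 3 percentage points lower from compound 2 to compound 3 (within the scatter) and the near-identical values suggest no movement beyond the scatter. Compound 4 is therefore expected at 104%, range 95% to 113%, an estimated step of a number 3 percentage points lower from compound 2 to compound 4 (within the scatter).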

Compound 4, a percentage reported as activity, at one concentration (the size of the read-out at that concentration, not a potency): 109%
The estimate for compound 4 lay 5 percentage points below the measured number; measured number inside the range.
By their numbers in this assay, from the lowest: compounds 1, 3, 2 and 4 (each within the scatter of the next).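

In this assay, the methoxy exchange on this aromatic ring now has measured steps in both directions: removing it gives a number 2 percentage points higher from compound 2 to compound 4 (within the scatter) and adding it gives a number 5 percentage points higher from compound 1 to compound 4 (within the scatter) as the second reading. Both steps lie within the scatter, so among compound 1, compound 2 and compound 4 the presence or absence of this methoxy has no readable effect at this single concentration. No measurement at hand bears on the reason for this result.

On these data alone, whether a hydroxy group or a chlorine atom in place of this methoxy would move the number beyond the scatter remains open. Also open, as far as these compounds go, is whether this methoxy matters at a concentration where these compounds show a clear effect on the cells.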